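A few compounds are considered here, and "the series" means these few. Any claim that something is new, unique, unknown or untested is made for them only; others in the source may bear on it.

Working notes on the series. In a functional assay on Vero cells (Chlorocebus sabaeus) for inhibition (a lower number here means a stronger inhibitor, a higher number a weaker inhibitor), compound 1 `CNc1ncnc2c1ncn2[C@@H]1CS[C@@H](CO)O1` reads > 100000 nM, which is a limit and not a number. Compound 2 `Cc1cn([C@H]2CS[C@@H](CO)O2)c(=O)nc1N` reads > 100000 nM, also a limit. Compound 3 `CNc1ncnc2c1ncn2[C@H]1CS[C@@H](CO)O1` reads > 100000 nM, again a limit. The picture so far is the limit of > 100000 nM in this assay, at which 3 of the 3 values shown sit, so compound 3 cannot be ranked against the other two.

The next compound is compound 4 `OC[C@H]1O[C@@H](n2cnc3c(Cl)ncnc32)CS1`, and the change is chloro in place of methylamino on an aromatic carbon. Going by the values given here, only one measured step exists, a step that the two limits leave unreadable from compound 1 to compound 3, and it does not touch this group, as it reflects (the fact that compounds 1 and 3 differ only in the configuration as drawn). It gives no size to carry over, so the effect of the swap is not known from the data. Among the compounds with values here, the sole anchor is compound 3 at > 100000 nM, a limit. Within the data shown here, with no compound yet giving a number in this assay, no step beyond the scatter is expected, though a modest move towards stronger inhibition cannot be excluded. The expected step of a number no higher from compound 3 to compound 4 (the limit leaves the size open) is an estimate that rests on that limit alone. Compound 4 is expected at about 100000 nM, with an estimated range of 20000 nM to 200000 nM.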

Compound 4, half-maximal inhibitory concentration: 46500 nM
The estimate for compound 4 lay 2.2-fold (0.33 log units) above the measured number; the measured number falls inside the stated range.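

In this assay, chloro in place of methylamino on this aromatic carbon gives the first readable move in the series, an at least 2.1-fold lower number from compound 3 to compound 4 (0.33 log units; beyond the scatter). Going by these compounds alone, compound 4 therefore carries the only true number so far, and it shows that this position can shift the read-out, which the pair of compounds 1 and 3, differing only in configuration, could not show. Every other value shown is a limit: the limit of > 100000 nM in this assay, at which 3 of the 4 values shown sit.

The true size of the step stays open, and the compounds shown do not separate an effect of chloro itself from an effect of losing methylamino, so bromo, methoxy or a plain amino group on the same carbon would be the informative comparisons. It is also open whether the configuration at the saturated ring carbon matters once chloro is in place, since the partner of compound 4 with that centre inverted is not among the compounds shown, and the earlier pair offers only limits.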